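Adding a (methylsulfanyl)methyl group to compound 2

This account rests on a few compounds, and the source may have more. Where it says the series, first, only, none or still open, it means among the compounds named here.

Of the compounds shown here, two have been read so far in an ADME assay on MDBK cells (Bos taurus) for cytotoxicity, read by MTT assay, with a stated time of 96 h; a higher number here means that more compound is tolerated, a lower number that less compound is tolerated. Compound 1 `O=C(NC(=S)Nc1cccc(C(F)(F)F)c1)c1ccccc1` gives > 100000 nM, which is a limit of the assay and not a number. Compound 2 `CCNC(=S)Nc1cccc(C(F)(F)F)c1` gives > 100000 nM, which is also a limit. The position of compound 2 is therefore known only as a limit, and the picture so far is the limit of > 100000 nM in this assay, at which 2 of the 2 values shown sit.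

Compound 3 `CSCCCNC(=S)Nc1cccc(C(F)(F)F)c1` turns the ethyl of compound 2 into 3-(methylsulfanyl)propyl ((methylsulfanyl)methyl in place of hydrogen on a saturated chain carbon, two bonds along the chain from an amide-type nitrogen). Among the compounds with values here, no measured step gauges this change. Little or no movement beyond the scatter is expected in this assay, and any movement would be towards less compound tolerated, since compound 2 stands at > 100000 nM. The expected step of an at least 1.1-fold lower number from compound 2 to compound 3 (0.04 log units; that floor lies within the scatter) is small. For compound 3 the estimate is 90000 nM, with an estimated range of 35000 nM to 100000 nM.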

Compound 3, half-maximal cytotoxic concentration: > 100000 nM
Compound 3 was reported as a limit; the forecaster's own chance of this, stated with the estimate: 65%; at least 1.1-fold (0.04 log units) between middle value and limit.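

No step can be read from compound 2 to compound 3, because both values are limits: the limit of > 100000 nM in this assay, at which 3 of the 3 values shown sit.

The compounds shown leave open at what concentration any of them stops being tolerated in this assay, and whether the (methylsulfanyl)methyl group shifts that concentration.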